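The compounds below may be only part of what the source reports. "The series", "measured", "known", "first", "only" and "open" are said of these compounds alone.

Measured compounds: compound 1 `O=C(NO)c1ccc(NCc2nc(-c3ccccc3)nn2-c2ccc(Br)cc2)cc1`, 1730 nM; compound 2 `O=C(NO)c1ccc(NCc2nc(-c3ccccc3)nn2-c2ccccc2)cc1`, 112 nM.

In an assay on Sf9 cells for inhibition of protein deacetylase HDAC6 (Homo sapiens), read by fluorescence, with a stated time of 40 min (on this read-out lower numbers stand for stronger inhibition and higher numbers for weaker inhibition), compound 1 gives 1730 nM and compound 2 gives 112 nM. Within the data shown here, compound 2 stands lowest of the two numbers; the nearest is compound 1, separated by a 15-fold lower number from compound 1 to compound 2 (1.19 log units; beyond the scatter), the sole change there being hydrogen in place of bromo on an aromatic carbon.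

Compound 3 `O=C(NO)c1ccc(NCc2nc(-c3ccccc3)nn2-c2ccccc2Cl)cc1` has not been measured in this assay. It differs from compound 2 by chloro in place of hydrogen on an aromatic carbon: the chloro enters on an aromatic carbon of a six-membered aromatic ring of carbon only, ortho to a large group, so that phenyl becomes 2-chlorophenyl.

Among the measured compounds shown here, the only step bearing on this is a 15-fold lower number from compound 1 to compound 2 (1.19 log units; beyond the scatter), a large one, in which removing bromo lowered the number. The halogen now enters at another place and is chloro rather than bromo, so that step is only a rough guide. A step toward a higher number in this assay, smaller than the measured one, is expected for compound 3: a 3.1-fold higher number from compound 2 to compound 3 (0.49 log units; beyond the scatter). Compound 3 is therefore estimated at 350 nM, with a range from 120 nM to 1200 nM.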

Compound 3, half-maximal inhibitory concentration: 669 nM
Beside the measured number, compound 3's estimate is 1.9-fold (0.28 log units) below it; low and high end bracket the measured number.
By their numbers in this assay, from the lowest: compound 2; then compound 3; then compound 1.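

With hydrogen as the reference, a halogen on this phenyl now raises the number at two places rather than one: in this assay, chloro on an aromatic carbon ortho to a large group gives (a 6.0-fold higher number from compound 2 to compound 3 (0.78 log units; beyond the scatter)). Between the two halogenated compounds, 2-chlorophenyl in place of 4-bromophenyl gives (a 2.6-fold lower number from compound 1 to compound 3 (0.41 log units; beyond the scatter)), and compound 2 keeps the lowest number of the three, but halogen and place change together in that step and cannot be separated there. Nothing at hand explains why either halogen raises the number.

Open, from the compounds shown here alone, is whether 2-bromophenyl or 4-chlorophenyl would separate the halogen from its place. Also open, going by these compounds, is whether a group of another kind on this ring, such as methoxy, an amine or a carboxylic acid, would raise the number as well.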